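The source may report more compounds than this note shows. Statements on the series, on what has been measured and on what is new or still open speak of the compounds shown alone.

Measured so far, in a functional assay on OVCAR-8 cells (Homo sapiens) for cytotoxicity, read by sulforhodamine B assay, with a stated time of 48 h, tested at 10 uM; on this read-out higher numbers stand for a weaker effect at the one concentration tested and lower numbers for a stronger effect:

Compound 1, `COc1ccc(-c2cc(/C=C/C(=O)c3ccc(N)cc3)[nH]n2)cc1`, gives 9%.
Compound 2, `COc1ccc(C(=O)/C=C/c2cc(-c3cc(OC)c(OC)c(OC)c3)n[nH]2)cc1OC`, gives -89%.
Compound 3, `COc1ccc(-c2cc(/C=C/C(=O)c3ccc(N)cc3)[nH]n2)cc1OC`, gives 2%.

Compound 1 and compound 3 differ by methoxy in place of hydrogen on an aromatic carbon, and the step between them, a number 7 percentage points lower from compound 1 to compound 3 (within the scatter), is small. Compound 2 shows the lowest number of the three, and the difference between its core and the core of compound 1 is not broken down here.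

Compound 4, `COc1cc(C(=O)/C=C/c2cc(-c3cc(OC)c(OC)c(OC)c3)n[nH]2)cc(OC)c1OC`, differs from compound 2 by methoxy in place of hydrogen on an aromatic carbon. Its place is also meta to a methoxy group, which the place in compound 3 is not, so this is the same kind of change rather than the same change. In this assay the step of a number 9 percentage points higher from compound 2 to compound 4 (within the scatter) is expected to stay small, because the earlier step of a number 7 percentage points lower from compound 1 to compound 3 (within the scatter) lay within the scatter. Compound 4 is therefore estimated at -80%, between -100% and -30%.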

Compound 4, a percentage reported as activity, at one concentration (the size of the read-out at that concentration, not a potency): -76%
Compound 4: the middle estimate sits 4 percentage points below what was measured; the range from low to high includes it.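

In this assay, putting methoxy in place of hydrogen on an aromatic carbon gives a number 13 percentage points higher from compound 2 to compound 4 (beyond the scatter), and this step does not match the one seen on the other core: the same change on two cores in this assay, a number 7 percentage points lower (within the scatter) from compound 1 to compound 3 and a number 13 percentage points higher (beyond the scatter) from compound 2 to compound 4, 20 percentage points apart, beyond the scatter of two such steps. The same kind of change therefore cannot be assumed to have the same effect on every core in this series. For the compounds shown here, this does not show that the core alone sets the difference, since the new methoxy in compound 4 is meta to a methoxy group and the one in compound 3 is not, and two pairs give no general rule.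

The compounds shown leave open what a third core would do with this change. They also leave open how a hydroxyl group or a fluorine atom would compare with methoxy at this place.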